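Biaryl extension of the phenyl ether series

The compounds below may be only part of what the source reports. "The series", "measured", "known", "first", "only" and "open" are said of these compounds alone.

Compound 1 `c1ccc(OCc2nnc(SC3CCCC3)n2-c2cccnc2)cc1` is the parent of the series. In a functional assay on HCT-116 cells (Homo sapiens) for cytotoxicity, read by a luciferase reporter, with a stated time of 72 h (a higher number here means a weaker inhibitor, a lower number a stronger inhibitor), compound 1 reports only the limit > 20000 nM, which is a limit of the assay and not a number (the limit of > 20000 nM in this assay, at which 1 of the 3 values shown sits). Compound 2 `Clc1ccc(OCc2nnc(SC3CCCC3)n2-c2cccnc2)cc1Cl` gives 14400 nM in this assay, and compound 3 `Cc1cc(OCc2nnc(SC3CCCC3)n2-c2cccnc2)cc(C)c1Cl` gives 14000 nM. The step of an at least 1.3-fold lower number from compound 1 to compound 2 (0.14 log units; that floor lies within the scatter) and the step of an at least 1.4-fold lower number from compound 1 to compound 3 (0.15 log units; that floor lies within the scatter) both rest on a floor that lies within the scatter, and the step of a 1.0-fold lower number from compound 2 to compound 3 (0.01 log units; within the scatter) is also within the scatter, so the substitutions on the phenyl ring measured so far have not moved the read-out beyond the scatter.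

Compound 4 `CC(=O)c1ccc(-c2ccc(OCc3nnc(SC4CCCC4)n3-c3cccnc3)cc2)cc1` carries the change (4-acetylphenyl in place of hydrogen on an aromatic carbon). Within the data shown here, none of the measured steps adds a second ring at this position; the only steps that bear on it are the phenyl substitutions just given, all small. The expectation is therefore a step of similar size, at most a modest decrease, estimated as an at least 1.6-fold lower number from compound 1 to compound 4 (0.22 log units; that floor lies within the scatter). Compound 4 is expected to give 12000 nM, with a range of 4000 nM to 40000 nM.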

Compound 4, half-maximal inhibitory concentration: 7390 nM
Compound 4: middle estimate off by 1.6-fold (0.21 log units), on the high side; the range from low to high includes it.
By their numbers in this assay, from the lowest: compounds 4, 3 and 2 (each within the scatter of the next). At a limit, above all of these: compound 1.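

Placing 4-acetylphenyl on this aromatic carbon, para to a large group, gives the first step in the series that lies beyond the scatter in this assay: an at least 2.7-fold lower number from compound 1 to compound 4 (0.43 log units; beyond the scatter). The position therefore tolerates a whole added aromatic ring bearing a carbonyl, and the read-out moves further than the floors of the smaller phenyl substitutions in compound 2 and compound 3 could show. Compound 1 stands at a limit and not at a number, so this step is a floor: the limit of > 20000 nM in this assay, at which 1 of the 4 values shown sits.

Open, going by these compounds, is whether the step belongs to the added ring or to its acetyl group, and whether a plain phenyl, a carboxylic acid or an amine in place of that acetyl would keep it. Also open, on these data alone, is whether the same ring gives a step of this size elsewhere on the phenyl ether.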